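From phenyl to 2-chlorophenyl on compound 2

The source may report more compounds than this note shows. Statements on the series, on what has been measured and on what is new or still open speak of the compounds shown alone.

Of the compounds shown here, three have been measured in a functional assay on MIA PaCa-2 cells (Homo sapiens) for inhibition, read by MTT assay; a lower number here means a stronger inhibitor, a higher number a weaker inhibitor. Compound 1 `CN(C)C(=O)c1cc2cnc(NC3CCCCC3)nc2n1C1CCCC1` gives 25000 nM, and compound 3 `CN(C)C(=O)c1cc2cnc(Nc3ccc(N4CCNCC4)cn3)nc2n1Cc1ccccc1` gives 30400 nM. Compound 2 `O=C(Nc1ccccc1)c1cc2cnc(Nc3ccc(N4CCNCC4)cn3)nc2n1C1CCCC1` gives 2800 nM, the lowest of the three numbers and beyond the scatter from both others. Compound 4 `O=C(Nc1ccccc1Cl)c1cc2cnc(Nc3ccc(N4CCNCC4)cn3)nc2n1C1CCCC1` differs from compound 2 in one place: chloro in place of hydrogen on an aromatic carbon, ortho to a large group. Going by the values given here, no measured pair shows this change, so the expectation rests on the structures alone. In this assay, no step beyond the scatter is expected, with a slight lean towards a lower number. The expected change is a 1.4-fold lower number from compound 2 to compound 4 (0.15 log units; within the scatter). The estimated value for compound 4 is 2000 nM, within an expected range of 700 nM to 6000 nM.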

Compound 4, half-maximal inhibitory concentration: 2170 nM
Compound 4: the middle estimate sits 1.1-fold (0.04 log units) below what was measured; low and high end bracket the measured number.
By their numbers in this assay, from the lowest: compounds 4 and 2 (each within the scatter of the next); then compounds 1 and 3 (each within the scatter of the next).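

In this assay the first step measured on the phenyl of the phenylcarbamoyl group is a 1.3-fold lower number from compound 2 to compound 4 (0.11 log units; within the scatter), so compound 2 and compound 4 cannot be told apart. At this place, on an aromatic carbon ortho to a large group, chloro in place of hydrogen therefore leaves the reading within the scatter. Nothing available bears on the reason for this result.

The compounds shown leave open whether a larger group here, such as methoxy, an amine or a carboxylic acid, would give a step beyond the scatter.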